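Methyl addition on a fused bicyclic core: antiproliferative notes

The source may hold more compounds than are shown below. What is called first, only, known or untested is meant among the compounds shown, and "the series" means these compounds.

Measured compounds:
compound 1 `Cc1ccnc2nc(-c3cccc(Cl)c3)cc(O)c12`: 40.7 nM
compound 2 `Oc1cc(-c2ccc3ccccc3c2)nc2ncccc12`: 9120 nM
compound 3 `Cc1cc(C)c2c(O)cc(-c3cccc(Cl)c3)nc2n1`: 47.9 nM

In a functional assay on SF-295 cells (Homo sapiens) for antiproliferative activity (a higher number here means a weaker inhibitor of growth, a lower number a stronger inhibitor of growth), compound 1 gives 40.7 nM. Compound 3 `Cc1cc(C)c2c(O)cc(-c3cccc(Cl)c3)nc2n1` carries an added methyl and in this assay gives 47.9 nM. The change methyl in place of hydrogen on an aromatic carbon produces a 1.2-fold higher number from compound 1 to compound 3 (0.07 log units; within the scatter), so the methyl at that place leaves the number essentially unchanged.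

Compound 2 `Oc1cc(-c2ccc3ccccc3c2)nc2ncccc12` stands apart: in this assay compound 2 gives 9120 nM, the highest of the three numbers and well beyond the scatter from both compound 1 and compound 3. The difference between the core of compound 2 and the core of compound 1 is not broken down here.

Compound 4 `Cc1cnc2nc(-c3ccc4ccccc4c3)cc(O)c2c1` is not yet measured. Relative to compound 2 it carries methyl in place of hydrogen on an aromatic carbon. Among the compounds with values here, this is the same kind of change as the one from compound 1 to compound 3, but not the same: in compound 3 the methyl sits next to the ring nitrogen and meta to a methyl group, whereas in compound 4 it sits two atoms from the ring nitrogen with no second methyl present.

Within the data shown here, on the basis of the step of a 1.2-fold higher number from compound 1 to compound 3 (0.07 log units; within the scatter), the expectation for compound 4 is a step of a 1.1-fold higher number from compound 2 to compound 4 (0.04 log units; within the scatter), because the only measured example of this kind of change, a 1.2-fold higher number from compound 1 to compound 3 (0.07 log units; within the scatter), lies within the scatter. Accordingly compound 4 is estimated at 10000 nM in this assay, with a range of 4000 nM to 25000 nM. The estimate rests on a single measured step and on a different core, so it is held loosely.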

Compound 4, concentration for 50% growth inhibition: 550 nM
For compound 4 the middle estimate is 18-fold (1.26 log units) above the measured one; the whole stated range lies above it.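

In this assay, methyl in place of hydrogen on an aromatic carbon gives a 17-fold lower number from compound 2 to compound 4 (1.22 log units; beyond the scatter), so on this core a single added methyl is enough for a large drop in the number, and the change does not carry from one core to the other as a fixed increment: the same change on two cores in this assay, a 1.2-fold higher number (0.07 log units; within the scatter) from compound 1 to compound 3 and a 17-fold lower number (1.22 log units; beyond the scatter) from compound 2 to compound 4, 20-fold (1.29 log units) apart, beyond the scatter of two such steps A methyl that leaves the number essentially unchanged on the core of compound 1 therefore gives no safe forecast for the core of compound 2. Within the data shown here, what this does not show is why the two steps part, since compound 1 and compound 2 differ in more than one place, the added methyl does not stand at the same place in the two pairs, and each core supplies only one step, so the part played by the core cannot be separated from the part played by the position of the methyl.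

On these data alone, it remains open whether the same place, two atoms from the ring nitrogen, would give a comparable step on the core of compound 1 with the other groups kept as they are. As far as these compounds go, it is also open whether the drop is specific to methyl or would extend to an ethyl group, a methoxy group, a chlorine atom or an amine at that carbon of compound 2.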